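Flipping One Stereocentre in a Potent Fatty Acid Receptor Agonist

The source may hold more compounds than are shown below. What is called first, only, known or untested is meant among the compounds shown, and "the series" means these compounds.

Compound 1 `COc1ccc(F)c([C@H]2CC[C@H](COc3cccc([C@@H](CC(=O)O)C4CC4)c3)CC2)c1` gives 4.1 nM in a functional assay on HEK293 cells for agonist activity at Free fatty acid receptor 1 (Rattus norvegicus), read by FLIPR and calcium flux; a higher number here means that more compound is needed for the effect, a lower number that less compound is needed. Among the compounds with values here, compound 2 `COc1ccc(F)c([C@H]2CC[C@H](COc3cccc([C@H](C4CC4)[C@@](C)(F)C(=O)O)c3)CC2)c1` gives 0.34 nM in this assay, the lower of the two numbers, and the single measured step, a 12-fold lower number from compound 1 to compound 2 (1.08 log units; beyond the scatter), came with a change of the acid-bearing group, not of configuration. Compound 3 `COc1ccc(F)c([C@H]2CC[C@H](COc3cccc([C@H](C4CC4)[C@](C)(F)C(=O)O)c3)CC2)c1` differs from compound 2 by the two compounds have the same atoms and bonds and differ only in configuration as drawn: 1 of 4 stereo elements differ; a stereocentre at a saturated chain carbon is drawn R in compound 2 and S in compound 3. Within the data shown here, no measured step tests such a change alone, so the expectation is loose; because compound 2 already gives 0.34 nM, the number is expected to rise rather than fall. Compound 3 is estimated at 3 nM, within 0.5 nM to 30 nM. The expected step is an 8.8-fold higher number from compound 2 to compound 3 (0.95 log units; beyond the scatter).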

Compound 3, half-maximal effective concentration: 6.9 nM
For compound 3 the middle estimate is 2.3-fold (0.36 log units) below the measured one, within the range that was stated.
By their numbers in this assay, from the lowest: compound 2; then compounds 1 and 3 (each within the scatter of the next).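

Redrawing one stereocentre at a saturated chain carbon gives a 20-fold higher number from compound 2 to compound 3 (1.31 log units; beyond the scatter) and this can be assigned to that stereocentre alone, because nothing else separates the pair: the fact that compounds 2 and 3 differ only in the configuration as drawn. The 1-carboxy-1-fluoroethyl group therefore brings a lower number than carboxymethyl only as drawn in compound 2. Drawn the other way, it shows a 1.7-fold higher number from compound 1 to compound 3 (0.23 log units; within the scatter) and cannot be told apart from carboxymethyl.

As far as these compounds go, whether this stereocentre matters as much with a hydroxyl or a chlorine in place of the fluorine stays open. So does how much of the drop in compound 2 belongs to the fluorine and how much to the extra methyl.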